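The source may report more compounds than this note shows. Statements on the series, on what has been measured and on what is new or still open speak of the compounds shown alone.

Compound 2, `C=C[C@@](C)(/C=C/c1ccc(O)c(CO)c1)CCC=C(C)C`, gives > 52000 nM in a functional assay on HepG2 cells (Homo sapiens) for cytotoxicity, with a stated time of 72 h (a lower number here means that less compound is needed, a higher number that more compound is needed for the effect), which is a limit and not a number. Compound 1, `C=C[C@@](C)(/C=C/c1ccc(O)cc1)CC/C=C/C(=O)OCc1ccccc1`, gives > 52000 nM in this assay, also a limit and not a number. Among the measured compounds shown here, the two compounds therefore stand together at the limit of > 52000 nM in this assay, at which 2 of the 2 values shown sit, and no measured step connects them.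

Compound 3, `C=C[C@@](C)(/C=C/c1ccc(O)c(/C=C/C(=O)O)c1)CCC=C(C)C`, has not yet been measured. Relative to compound 2, it carries 2-carboxyethenyl in place of hydroxymethyl on an aromatic carbon, ortho to a hydroxy group and meta to a large group: 2-carboxyethenyl in place of hydroxymethyl on an aromatic carbon. For the measured compounds named here, no measured step gives the size of this change.

With compound 2 resting on the limit > 52000 nM, the expectation in this assay is for no step beyond the scatter, and no direction can be named. Another reading reported only as a limit is the likeliest outcome. The estimated change is a step that the limit leaves unreadable from compound 2 to compound 3. For compound 3 the expected value is 55000 nM, with an estimated range of 25000 nM to 100000 nM.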

Compound 3, half-maximal effective concentration: > 52000 nM
Compound 3: only a limit was reported; the forecaster's own chance of this, stated with the estimate: 75%; the middle value lies beyond the limit too.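

In this assay compound 3 gives > 52000 nM as a limit and not a number. Among the compounds shown here, no step from compound 2 to compound 3 can be read, because both readings are limits: the limit of > 52000 nM in this assay, at which 3 of the 3 values shown sit. The compounds shown leave open what size of change, if any, 2-carboxyethenyl in place of hydroxymethyl on an aromatic carbon brings in this read-out.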